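Dropping the whole side chain from compound 1

A few compounds are considered here, and "the series" means these few. Any claim that something is new, unique, unknown or untested is made for them only; others in the source may bear on it.

Compound 1 `COc1cccc(CNC(=O)c2cn(CCN(C)C)c3cc(-c4cn[nH]c4)ccc23)c1` is measured in an assay on isolated protein for inhibition of Rho-associated protein kinase 1 (Homo sapiens) (a lower number here means a stronger inhibitor, a higher number a weaker inhibitor), where compound 1 gives 5 nM. Of the two plain numbers shown, this is the lower one: compound 3 `COc1cccc(CN(C)C(=O)c2c[nH]c3cc(-c4cn[nH]c4)ccc23)c1` gives 19 nM in this assay, a gap beyond the usual scatter. For compound 2 `COc1cccc(CNC(=O)c2cn(C)c3cc(-c4cn[nH]c4)ccc23)c1` this assay returns only a limit, < 1 nM, not a number (the limit of < 1 nM in this assay, at which 1 of the 3 values shown sits).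

Compound 4 `COc1cccc(CNC(=O)c2c[nH]c3cc(-c4cn[nH]c4)ccc23)c1` differs from compound 1 by hydrogen in place of 2-(dimethylamino)ethyl on an aromatic nitrogen. Within the data shown here, one measured step bears on this: an at least 5.0-fold lower number from compound 1 to compound 2 (0.69 log units; beyond the scatter), which removed part of the same chain and made the number smaller. Removing the whole chain is expected to give a similar or somewhat lower number, with wide uncertainty. Compound 4 is therefore estimated at 3 nM in this assay, between 1 nM and 12 nM, meaning a 1.7-fold lower number from compound 1 to compound 4 (0.22 log units; within the scatter).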

Compound 4, half-maximal inhibitory concentration in the Rho-associated protein kinase 1 assay: < 1 nM
Compound 4: only a limit was reported (the forecaster's own chance of this, stated with the estimate: 20%); at least 3.0-fold (0.47 log units) between middle value and limit.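

In the Rho-associated protein kinase 1 assay, the hydrogen on this aromatic nitrogen gives an at least 5.0-fold lower number from compound 1 to compound 4 (0.69 log units; beyond the scatter), so the whole chain can go without loss here, and hydrogen on the amide-type nitrogen, a different place, gives an at least 19-fold lower number from compound 3 to compound 4 (1.27 log units; beyond the scatter); the step between compound 2 and compound 4 cannot be read, since it joins two limits. In a physicochemical assay for solubility, at pH 5.5 (a lower number here means a less soluble compound, a higher number a more soluble compound), compound 1 gives >= 100000 nM, which is a limit. In the physicochemical assay compound 4 gives <= 10 nM, also a limit.

Open, going by these compounds, is whether a shorter chain ending in an amine, or a chain ending in a carboxylic acid, on this aromatic nitrogen would hold both read-outs.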